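This account rests on a few compounds, and the source may have more. Where it says the series, first, only, none or still open, it means among the compounds named here.

Measured in a functional assay on MCF7 cells (Homo sapiens) for inhibition, read by sulforhodamine B assay; on this read-out lower numbers stand for stronger inhibition and higher numbers for weaker inhibition:
- compound 1 `O=C1C=C(N2CCC2)C(=O)c2c1nc1n2[C@H]2OC[C@@H](O)[C@H]2OC1`: > 16000 nM (a limit)
- compound 2 `CCc1ccc(NC2=CC(=O)c3c(nc4n3[C@H]3OC[C@@H](O)[C@H]3OC4)C2=O)cc1`: 8990 nM
- compound 3 `COc1ccccc1NC1=CC(=O)c2c(nc3n2[C@H]2OC[C@@H](O)[C@H]2OC3)C1=O`: 6580 nM

Compound 1 has no number of its own and stands at the limit of > 16000 nM in this assay, at which 1 of the 3 values shown sits.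

Compound 4 `CCc1ccc(NC2=CC(=O)c3nc4n(c3C2=O)[C@H]2OC[C@@H](O)[C@H]2OC4)cc1` departs from compound 1 in one place: (4-ethylphenyl)amino in place of azetidin-1-yl on a double-bonded ring carbon. In words, (4-ethylphenyl)amino replaces azetidin-1-yl on a double-bonded ring carbon. Among the compounds with values here, no measured step covers this exchange, so the evidence is indirect. Compound 2 carries the same (4-ethylphenyl)amino group, though on a core not identical to that of compound 4. Compound 2 gives 8990 nM. Within the data shown here, the one measured step, a 1.4-fold lower number from compound 2 to compound 3 (0.14 log units; within the scatter), changes only the group on the amine nitrogen, and compound 3 gives 6580 nM.

On the strength of compound 2 at 8990 nM, compound 4 is expected to return a real number in the same region. The expected change in this assay is an at least 2.2-fold lower number from compound 1 to compound 4 (0.35 log units; beyond the scatter), toward a lower number, with its true size uncertain. The estimate for compound 4 is 7000 nM, with an expected range of 2500 nM to 16000 nM.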

Compound 4, half-maximal inhibitory concentration: 960 nM
Beside the measured number, compound 4's estimate is 7.3-fold (0.86 log units) above it, and the stated range ends above it.
By their numbers in this assay, from the lowest: compound 4; then compounds 3 and 2 (each within the scatter of the next). At a limit, above all of these: compound 1.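

In this assay, within the data shown here, this double-bonded ring carbon now gives the first step on the core of compound 1 that can be read as beyond the scatter: an at least 16-fold lower number from compound 1 to compound 4 (1.22 log units; beyond the scatter). On this core, (4-ethylphenyl)amino gives a measured value where azetidin-1-yl leaves only a limit. The true size of the step stays open because compound 1 stands at a limit and not at a number: the limit of > 16000 nM in this assay, at which 1 of the 4 values shown sits.

The compounds shown leave open whether the aromatic ring or the hydrogen on the amine nitrogen carries this change, which a cyclohexylamino group or an N-methyl-N-phenylamino group at this carbon would separate. Also open, from the compounds shown here alone, is whether 2-methoxyphenyl in place of 4-ethylphenyl on the amine nitrogen, which gives a 1.4-fold lower number from compound 2 to compound 3 (0.14 log units; within the scatter) on the other core, would act the same way on the core of compound 4.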